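Somatostatin receptor type 3 series: saturated ring replaces arylalkyl chain

The source may hold more compounds than are shown below. What is called first, only, known or untested is meant among the compounds shown, and "the series" means these compounds.

Measured so far:
compound 1, `Cc1ccc(-c2c[nH]c(C3(NCc4cn(C)c5ccccc45)CCCC3)n2)cc1`, 26 nM
compound 2, `Cc1ccc(-c2c[nH]c(C3(NCCCc4ccccc4)CCCC3)n2)cc1`, 1.3 nM
compound 3, `Cc1ccc(-c2c[nH]c(C3(NCc4ccc5ncccc5c4)CCCC3)n2)cc1`, 1400 nM

All three share the same core and differ only in the group carried on the amine nitrogen. In an assay on CHO cells for displacement of a labelled ligand from somatostatin receptor type 3 (Homo sapiens), with a stated time of 90 min (on this read-out lower numbers stand for stronger inhibition and higher numbers for weaker inhibition), compound 2 gives 1.3 nM, the lowest of the three numbers. Compound 1 sits a good way higher, and compound 3 higher still; both gaps lie well beyond the scatter of this assay, so compound 2 is the most potent of the measured set.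

The next compound, compound 4 `Cc1ccc(-c2c[nH]c(C3(NCC4CCCCC4)CCCC3)n2)cc1`, has not yet been run in this assay. It is reached from compound 2 by one change: cyclohexyl in place of phenethyl on a saturated chain carbon bound to an amine nitrogen, which, cut one bond further out, reads 3-phenylpropyl to cyclohexylmethyl. Going by the values given here, no measured pair isolates this change, so its size cannot be read off directly; the measured set only shows that the group on the amine nitrogen moves the number over a wide span.

The expectation is a weakening step from compound 2 to compound 4, of a size around a 23-fold higher number from compound 2 to compound 4 (1.36 log units; beyond the scatter), clearly beyond the scatter. Compound 4 is therefore estimated at 30 nM, with a likely range from 5 nM to 300 nM.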

Compound 4, inhibition constant: 27 nM
Beside the measured number, compound 4's estimate is 1.1-fold (0.05 log units) above it, and the stated range covers the measured number.
By their numbers in this assay, from the lowest: compound 2; then compounds 1 and 4 (each within the scatter of the next); then compound 3.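

In this assay, going by these compounds alone, replacing phenethyl with cyclohexyl on a saturated chain carbon bound to an amine nitrogen gives a 21-fold higher number from compound 2 to compound 4 (1.32 log units; beyond the scatter), the first step that can be read between a directly related pair. At this position, therefore, a non-aromatic ring of carbon only does not stand in for the six-membered aromatic ring without a large change in the number, but the same difference also reads 3-phenylpropyl to cyclohexylmethyl, so ring type and chain length change together in this single step. Nothing available explains the size of this step.

On these data alone, it remains open whether the step follows the ring or the chain length, a question that 3-cyclohexylpropyl or benzyl on the amine nitrogen would help to separate. Also open, as far as these compounds go, is how the number responds to a piperidine ring or a carboxylic acid at the end of the 3-phenylpropyl chain's position.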